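Replacing a Carboxy Group with Two Methyl Groups

A few compounds are considered here, and "the series" means these few. Any claim that something is new, unique, unknown or untested is made for them only; others in the source may bear on it.

Three amides built on one shared core have been measured in an assay on HEK293 cells for displacement of a labelled ligand from metabotropic glutamate receptor 5 (Rattus norvegicus); on this read-out lower numbers stand for stronger inhibition and higher numbers for weaker inhibition. Compound 1 `COc1cccc(C(=O)Nc2cc(-c3ccccc3)nn2-c2ccccc2)c1` gives 1290 nM. Compound 2 `COc1ccc(C(=O)Nc2cc(-c3ccccc3)nn2-c2ccccc2)cc1` gives 420 nM, which is a 3.1-fold lower number from compound 1 to compound 2 (0.49 log units; beyond the scatter). For compound 3 `O=C(O)c1ccc(C(=O)Nc2cc(-c3ccccc3)nn2-c2ccccc2)cc1`, the reading of > 10000 nM is a limit of the assay rather than a number. Compound 3 thus sits at the weak end of everything measured so far, as shown by an at least 7.7-fold higher number from compound 1 to compound 3 (0.88 log units; beyond the scatter) and by an at least 23-fold higher number from compound 2 to compound 3 (1.37 log units; beyond the scatter), both running into (the limit of > 10000 nM in this assay, at which 1 of the 3 values shown sits).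

Compound 4 `Cc1ccc(C(=O)Nc2cc(-c3ccccc3)nn2-c2ccccc2)cc1C` has not yet been measured in this assay. The change from compound 3 is 3,4-dimethylphenyl in place of 4-carboxyphenyl on a carbonyl carbon. Going by the values given here, the steps that bear on it are an at least 23-fold higher number from compound 2 to compound 3 (1.37 log units; beyond the scatter) and an at least 7.7-fold higher number from compound 1 to compound 3 (0.88 log units; beyond the scatter), both moving toward weaker binding as the carboxy group comes in; the present change removes that group again, so a return toward the numbers seen for compound 1 and compound 2 is expected. Compound 4 is expected to come in near 600 nM, somewhere between 150 nM and 2500 nM. This estimate amounts to an expected step of an at least 16-fold lower number from compound 3 to compound 4 (1.22 log units; beyond the scatter).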

Compound 4, inhibition constant: 430 nM
For compound 4 the middle estimate is 1.4-fold (0.14 log units) above the measured one; the range from low to high includes it.
By their numbers in this assay, from the lowest: compounds 2 and 4 (each within the scatter of the next); then compound 1. At a limit, above all of these: compound 3.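

In this assay, taking out the 4-carboxyphenyl group and putting in 3,4-dimethylphenyl on the carbonyl carbon restores measurable binding, with an at least 23-fold lower number from compound 3 to compound 4 (1.36 log units; beyond the scatter). The true size of this step stays unknown, as the reading for compound 3 is a limit: the limit of > 10000 nM in this assay, at which 1 of the 4 values shown sits.

Against the 4-methoxyphenyl amide the new group reads alike, with a 1.0-fold higher number from compound 2 to compound 4 (0.01 log units; within the scatter), and against the 3-methoxyphenyl amide there is a 3.0-fold lower number from compound 1 to compound 4 (0.48 log units; beyond the scatter), so a group of carbon only, with 0 hydrogen-bond acceptors, serves at this place as well as the 4-methoxyphenyl group does.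

As far as these compounds go, whether one methyl group alone would give the same reading remains open, as the two methyl groups appear here only together. Also open, from the compounds shown here alone, is how an amine or a longer alkyl chain on this ring would read.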